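A few compounds are considered here, and "the series" means these few. Any claim that something is new, unique, unknown or untested is made for them only; others in the source may bear on it.

Of the compounds shown here, three have so far been tested in a functional assay on CHO cells for antagonist activity at sphingosine 1-phosphate receptor 2 (Homo sapiens), read by fluorescence and calcium flux, with a stated time of 3 min; a higher number here means a weaker inhibitor, a lower number a stronger inhibitor. Compound 1 `Cc1cc(NNC(=O)Nc2cc(Cl)nc(Cl)c2)ncc1-c1cn(C)nc1C` gives no number but only (the limit of > 1400 nM in this assay, at which 1 of the 3 values shown sits), reported as > 1400 nM. Compound 2 `Cc1cc(NNC(=O)Nc2cc(Cl)nc(Cl)c2)nc(-c2cnn(C)c2)c1` likewise stops at the limit of > 2100 nM in this assay, at which 1 of the 3 values shown sits, reported as > 2100 nM. Compound 3 `CCOc1cc(NC(=O)NCc2cc(C)c(-c3cn(C)nc3C(F)(F)F)nn2)cc(C#N)n1` is the single one that yields a real figure: in this assay compound 3 shows 11000 nM, so compound 3 stands as the only measured point.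

Compound 4 `CCOc1cc(NC(=O)NCc2cc(C)c(-c3cn(C)nc3C(F)(F)F)nn2)cc(C)n1` differs from compound 3 in one place: methyl in place of cyano on an aromatic carbon, in words methyl in place of cyano on an aromatic carbon of a six-membered aromatic ring with one nitrogen, next to the ring nitrogen. Among the compounds with values here, no pair of measured compounds shows the effect of such a swap, so its size is unknown. In this assay the change is expected to stay within the usual scatter, with no clear direction. Compound 4 is therefore estimated at 10000 nM, in a range from 3000 nM to 35000 nM. The step of a 1.1-fold lower number from compound 3 to compound 4 (0.04 log units; within the scatter) is expected to be small.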

Compound 4, half-maximal inhibitory concentration: 54000 nM
Beside the measured number, compound 4's estimate is 5.4-fold (0.73 log units) below it; the measured number lies above the stated range.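

In this assay, placing methyl in place of cyano on an aromatic carbon next to the ring nitrogen gives a 4.9-fold higher number from compound 3 to compound 4 (0.69 log units; beyond the scatter), so this position does respond to what it carries. Within the data shown here, this is the first comparison between compounds that differ in one place, and compound 4 is the weaker inhibitor of the pair. By simple count, cyano brings one hydrogen-bond acceptor and methyl none, but this single pair cannot separate that difference from the others between the two groups.

Nothing measured here gives a reason for the step. As far as these compounds go, how an amine, a carboxylic acid or a longer chain would fare at this position remains open, as does whether the same swap would act alike on another core.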